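The source may report more compounds than this note shows. Statements on the series, on what has been measured and on what is new or still open speak of the compounds shown alone.

Measured so far in a functional assay on a cell-free system (plasma) with sterol O-acyltransferase, Soat (Rattus norvegicus) as the target; on this read-out lower numbers stand for an effect already at smaller amounts and higher numbers for an effect only at larger amounts of compound:
Compound 1 `CSc1cc(C)nc(SC)c1NC(=O)N(Cc1ccccc1)Cc1cccc(-c2cnn(C)c2)c1`: > 0.1 mg/kg, a limit of the assay and not a number.
Compound 2 `O=C(Nc1c(F)cc(F)cc1F)N(Cc1ccc(-c2ccccn2)cc1)C1CCCCCC1`: > 1 mg/kg, a limit.
Compound 3 `Cc1cc(C)c(NC(=O)N(Cc2ccc(-c3ccccn3)cc2)C2CCCCCC2)c(C)c1`: > 1 mg/kg, a limit.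

Compound 3 thus stands at a limit rather than at a number. All three values shown are limits: the limit of > 0.1 mg/kg in this assay, at which 1 of the 3 values shown sits, and (the limit of > 1 mg/kg in this assay, at which 2 of the 3 values shown sit). Within the data shown here, the one step between compounds that differ in a single place, a step that the two limits leave unreadable from compound 2 to compound 3, cannot be read from these limits. Compound 4 `Cc1cc(C)c(NC(=O)N(Cc2ccc(-n3ccnc3)cc2)C2CCCCCC2)c(C)c1` differs from compound 3 by 1H-imidazol-1-yl in place of pyridin-2-yl on an aromatic carbon. Among the measured compounds shown here, no measured step bears on this change with a readable size, so no direction is expected for a step that the limit leaves unreadable from compound 3 to compound 4, and the result for compound 4 is expected to come out again as a limit. The estimate for compound 4 in this assay is 3 mg/kg, with a range from 0.5 mg/kg to 30 mg/kg.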

Compound 4, dose for half-maximal effect: > 1 mg/kg
Compound 4: no number, only a limit; the forecaster's own chance of this, stated with the estimate: 70%; the middle value lies beyond the limit too.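

No new step can be read, since compound 3 and compound 4 both stand at a limit of the assay and not at a number: the limit of > 1 mg/kg in this assay, at which 3 of the 4 values shown sit. The compounds shown leave open whether 1H-imidazol-1-yl and pyridin-2-yl differ at all in this assay.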